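Pyridin-4-yl in Place of Phenyl in Compound 3

The compounds below may be only part of what the source reports. "The series", "measured", "known", "first", "only" and "open" are said of these compounds alone.

In a functional assay on Pfeiffer cells (Homo sapiens) for inhibition, read by CCK-8 assay (a lower number here means a stronger inhibitor of growth, a higher number a weaker inhibitor of growth), compound 1 `O=S(=O)(Nc1cc(-c2cnc3[nH]ncc3c2)cnc1Cl)c1ccccc1` gives 1160 nM. Compound 2 `O=S(=O)(Nc1cc(-c2cnc3[nH]nc(-c4ccccc4)c3c2)cnc1Cl)c1ccccc1` gives 1300 nM.

Compound 2 holds the higher of the two numbers, with compound 1 nearest, and the step of a 1.1-fold higher number from compound 1 to compound 2 (0.05 log units; within the scatter) lies within the scatter. Compound 3 `O=S(=O)(Nc1cc(-c2cnc3[nH]nc(-c4ccncc4)c3c2)cnc1Cl)c1ccccc1` differs from compound 2 by pyridin-4-yl in place of phenyl on an aromatic carbon. For the measured compounds named here, the only measured step, a 1.1-fold higher number from compound 1 to compound 2 (0.05 log units; within the scatter), shows that adding phenyl at this carbon left the number unchanged; no measured pair exchanges phenyl for pyridin-4-yl. Compound 3 is therefore expected to show no step beyond the scatter, a 1.1-fold lower number from compound 2 to compound 3 (0.03 log units; within the scatter). The estimate for compound 3 is 1200 nM, within 500 nM to 3000 nM.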

Compound 3, concentration for 50% growth inhibition: 150 nM
For compound 3 the middle estimate is 8.0-fold (0.90 log units) above the measured one, outside the stated range (below it).
By their numbers in this assay, from the lowest: compound 3; then compounds 1 and 2 (each within the scatter of the next).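

The carbon is not indifferent to what it carries: phenyl in place of hydrogen gave a 1.1-fold higher number from compound 1 to compound 2 (0.05 log units; within the scatter), yet pyridin-4-yl in place of phenyl gives an 8.7-fold lower number from compound 2 to compound 3 (0.94 log units; beyond the scatter). Pyridin-4-yl in place of hydrogen gives a 7.7-fold lower number from compound 1 to compound 3 (0.89 log units; beyond the scatter), so at this carbon the ring with one nitrogen lowers the number where the ring of carbon only did not. Nothing at hand explains this difference. On these data alone, whether pyridin-3-yl or pyrimidin-5-yl at this carbon would give a similar number stays open, as does the outcome with a simple amine there.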